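Adding a hydroxy group on a second core

The source may hold more compounds than are shown below. What is called first, only, known or untested is meant among the compounds shown, and "the series" means these compounds.

Compound 1 `CN1CCC[C@H]1COc1cccc(C#CCCCCO)c1` was tested in an assay on HEK243 cells for displacement of a labelled ligand from Neuronal acetylcholine receptor; alpha3/beta4 (Homo sapiens), read by scintillation counting, with a stated time of 5 min (on this read-out lower numbers stand for stronger inhibition and higher numbers for weaker inhibition), where compound 1 gives 8300 nM. Compound 2 `CN1CCC[C@H]1COc1cc(O)cc(C#CCCCCO)c1` carries one extra group, (hydroxy in place of hydrogen on an aromatic carbon), and in this assay compound 2 gives 3100 nM. That single change produced a 2.7-fold lower number from compound 1 to compound 2 (0.43 log units; beyond the scatter). Compound 3 `CN1CCC[C@H]1COc1cc(-c2ccccc2)cc([N+](=O)[O-])c1` is built on a different core; the difference between the two cores is not broken down here. In this assay, for the measured compounds named here, compound 3 gives 947 nM, the lowest of the three numbers so far. Compound 4 `CN1CCC[C@H]1COc1cc(-c2ccc(O)cc2)cc([N+](=O)[O-])c1` has not yet been measured and differs from compound 3 by hydroxy in place of hydrogen on an aromatic carbon. Going by the values given here, this is the same kind of change as the one that turned compound 1 into compound 2, but not the same: in compound 2 the hydroxy sits meta to a 6-hydroxyhex-1-yn-1-yl group, while in compound 4 it sits para to a large group, turning a phenyl into a 4-hydroxyphenyl. The expectation rests on that single measured example, because a 2.7-fold lower number from compound 1 to compound 2 (0.43 log units; beyond the scatter) was a modest gain on another core. The step from compound 3 to compound 4 is therefore expected to be a 2.4-fold lower number from compound 3 to compound 4 (0.37 log units; beyond the scatter). Compound 4 is estimated at 400 nM in this assay, with a likely range from 150 nM to 1100 nM.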

Compound 4, inhibition constant: 122 nM
For compound 4 the middle estimate is 3.3-fold (0.52 log units) above the measured one, outside the stated range (below it).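

Turning the phenyl into a 4-hydroxyphenyl gave a 7.8-fold lower number from compound 3 to compound 4 (0.89 log units; beyond the scatter) in this assay. The hydroxy group lowered the number on both cores, so the direction of the change carried across, but its size did not: the same change on two cores in this assay, a 2.7-fold lower number (0.43 log units; beyond the scatter) from compound 1 to compound 2 and a 7.8-fold lower number (0.89 log units; beyond the scatter) from compound 3 to compound 4, 2.9-fold (0.46 log units) apart, beyond the scatter of two such steps. For the compounds shown here, with only two pairs, this shows that the size of the gain can differ between cores, but it does not show which difference between the cores goes with the larger step, nor does it give a rule for predicting the step on a further core.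

On these data alone, it remains open whether a methoxy group or an amine in the same place on the phenyl ring would give a step of similar size to that of the hydroxy group. As far as these compounds go, it is also open how large the hydroxy step would be if a carboxylic acid stood in place of the nitro group on the core of compound 3.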